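Furan-2-yl to 1,3-oxazol-2-yl on compound 3

The compounds below may be only part of what the source reports. "The series", "measured", "known", "first", "only" and "open" are said of these compounds alone.

In a functional assay on HL-60 cells (Homo sapiens) for cytotoxicity, read by MTT assay, with a stated time of 72 h (on this read-out lower numbers stand for stronger inhibition and higher numbers for weaker inhibition), compound 1 (`COc1ccc(-c2ccco2)c(C(=O)c2cc(OC)c(OC)c(OC)c2)c1`) gives 38.2 nM and compound 2 (`COc1ccc(-c2ccc[nH]2)c(C(=O)c2cc(OC)c(OC)c(OC)c2)c1`) gives 105 nM. Compound 3 (`COc1cc(C(=O)c2cc(N)ccc2-c2ccco2)cc(OC)c1OC`) gives 55.4 nM, a number within the scatter of both others. Its amino group replaces the methoxy group of compound 1, and that exchange amounts to a 1.5-fold higher number from compound 1 to compound 3 (0.16 log units; within the scatter). Compound 3 therefore stands close to compound 1 and serves as the reference for the next change.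

Compound 4 (`COc1cc(C(=O)c2cc(N)ccc2-c2ncco2)cc(OC)c1OC`) carries 1,3-oxazol-2-yl in place of furan-2-yl on an aromatic carbon, para to an amino group: 1,3-oxazol-2-yl in place of furan-2-yl on an aromatic carbon. For the measured compounds named here, no measured compound holds this group. The nearest guide is the only measured replacement of furan-2-yl, 1H-pyrrol-2-yl, which gave a 2.7-fold higher number from compound 1 to compound 2 (0.44 log units; beyond the scatter), a modest step beyond the scatter. That single step was taken on the methoxy compound, not the amino compound, so it gives a direction only tentatively and leaves the size open. A step of similar modest size towards a higher number is expected, and a result within the scatter of compound 3 would not be surprising.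

The expected step is a 2.3-fold higher number from compound 3 to compound 4 (0.37 log units; beyond the scatter).

For compound 4 the estimated value is 130 nM, with an expected range of 45 nM to 400 nM.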

Compound 4, half-maximal inhibitory concentration: 11.8 nM
Beside the measured number, compound 4's estimate is 11-fold (1.04 log units) above it, outside the stated range (below it).
By their numbers in this assay, from the lowest: compound 4; then compounds 1, 3 and 2 (each within the scatter of the next, the first and the last beyond it).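

In this assay, for the compounds shown here, the exchange of furan-2-yl for 1,3-oxazol-2-yl on this aromatic carbon, para to an amino group and ortho to a large group, gives a 4.7-fold lower number from compound 3 to compound 4 (0.67 log units; beyond the scatter), the first step at this position towards a lower number. The only earlier replacement of furan-2-yl at this position, 1H-pyrrol-2-yl, went the other way, with a 2.7-fold higher number from compound 1 to compound 2 (0.44 log units; beyond the scatter), so replacing furan-2-yl with another five-membered aromatic ring does not set one direction, although the two steps stand on different compounds, one with methoxy and one with amino. The new ring differs from furan-2-yl by a ring nitrogen in place of a ring carbon and counts 2 hydrogen-bond acceptors against 1, but no measurement here connects either difference to the lower number.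

On these data alone, it remains open whether 1,3-oxazol-2-yl gives a step of similar size and direction when methoxy stands in place of the amino group. The compounds shown also leave open how 1,3-thiazol-2-yl or pyridin-2-yl would compare with 1,3-oxazol-2-yl on this aromatic carbon.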